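Working notes on a C-type lectin binding series

The source may hold more compounds than are shown below. What is called first, only, known or untested is meant among the compounds shown, and "the series" means these compounds.

Measured compounds:
compound 1 `CN(C)C(=O)c1c[nH]c2ccc(N(C)C)cc2c1=O` – in an assay for binding affinity to C-type lectin domain family 4 member M (Homo sapiens), read by reporter gene assay and NMR (a lower number here means tighter binding, a higher number weaker binding), compound 1 gives no result reported
compound 2 `O=c1c(S(=O)(=O)c2ccccc2)c[nH]c2cc(F)ccc12` – in this assay compound 2 gives 1900000 nM

Among the measured compounds shown here, compound 1 stands without a number in this assay; the only measured anchor is compound 2, and its value shows very weak binding. For the measured compounds named here, no step between two measured compounds is available in this assay, so no direction or size of change can be set from the data.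

Compound 3 `CCOC(=O)c1c[nH]c2ccc(N(C)C)cc2c1=O` differs from compound 1 by one change: ethoxy in place of dimethylamino on a carbonyl carbon. Going by the values given here, with no value for compound 1 and no measured step, the expected size of the step in this assay cannot be stated beyond saying that nothing is known to push it past the scatter in either direction.

Compound 3 is therefore expected, on the weak-binding level that compound 2 shows with 1900000 nM, to give roughly 1500000 nM, within a range of 200000 nM to 10000000 nM, as an estimate only.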

Compound 3, dissociation constant: 300000 nM
Beside the measured number, compound 3's estimate is 5.0-fold (0.70 log units) above it; the measured number falls inside the stated range.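

In this assay, among the compounds shown here, compound 3 gives 300000 nM, but compound 1 has no number there, so no step between compound 1 and compound 3 can be read. On these data alone, whether dimethylcarbamoyl to ethoxycarbonyl changes binding, and in which direction, stays open. No further data bear on this result.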